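The source may hold more compounds than are shown below. What is called first, only, known or untested is meant among the compounds shown, and "the series" means these compounds.

Compound 1 `O[C@@H](c1ccccc1)[C@H]1CO[C@H](c2ccccc2)[C@@H](C/C=C/c2ccccn2)C1` gives 33800 nM in a functional assay on HeLa cells (Homo sapiens) for cytotoxicity, read by WST assay, with a stated time of 48 h; a higher number here means a weaker inhibitor, a lower number a stronger inhibitor.
Compound 2 `CCCCCC/C=C/C[C@H]1C[C@@H]([C@@H](O)c2ccccc2)CO[C@@H]1c1ccccc1` gives 7400 nM in this assay.
Compound 3 `O[C@@H](c1ccccc1)[C@H]1CO[C@H](c2ccccc2)[C@@H](C/C=C/c2ccc(F)cc2)C1` gives 8340 nM in this assay.

Compound 3 stands second highest of the three numbers. Its nearest neighbour is compound 2, and a 1.1-fold higher number from compound 2 to compound 3 (0.05 log units; within the scatter), so the two cannot be told apart. Its furthest neighbour is compound 1, and a 4.1-fold lower number from compound 1 to compound 3 (0.61 log units; beyond the scatter), a difference that is real.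

Compound 4 `O[C@@H](c1ccccc1)[C@H]1CO[C@H](c2ccccc2)[C@@H](C/C=C/c2ccccc2F)C1` has not yet been measured in this assay. Within the data shown here, its only difference from compound 3 is 2-fluorophenyl in place of 4-fluorophenyl on a double-bonded chain carbon bound to a double-bonded chain carbon. Among the measured compounds shown here, no measured step moves a fluorine around a ring, so nothing bears directly on this change. The steps that touch the same place are a 4.6-fold lower number from compound 1 to compound 2 (0.66 log units; beyond the scatter), a 4.1-fold lower number from compound 1 to compound 3 (0.61 log units; beyond the scatter) and a 1.1-fold higher number from compound 2 to compound 3 (0.05 log units; within the scatter). They show that exchanging a pyridin-2-yl for either a hexyl or a 4-fluorophenyl lowers the number modestly, while hexyl and 4-fluorophenyl, two quite unlike groups, sit within the scatter of each other. Moving one fluorine on the same ring is a far smaller change than either of those, so the expected step in this assay is none beyond the scatter, with a 1.0-fold lower number from compound 3 to compound 4 (0.02 log units; within the scatter) as the working estimate.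

Compound 4 is therefore expected to give about 8000 nM in this assay, within a range from 4000 nM to 17000 nM.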

Compound 4, half-maximal inhibitory concentration: 9730 nM
The estimate for compound 4 lay 1.2-fold (0.09 log units) below the measured number, within the range that was stated.
By their numbers in this assay, from the lowest: compounds 2, 3 and 4 (each within the scatter of the next); then compound 1.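

In this assay, moving the fluorine from 4-fluorophenyl to 2-fluorophenyl at this place on the chain produces no change that can be told apart, with a 1.2-fold higher number from compound 3 to compound 4 (0.07 log units; within the scatter), so where the fluorine sits on this ring makes no visible difference in the two arrangements shown. Among these compounds, the 2-fluorophenyl group also cannot be separated from hexyl, with a 1.3-fold higher number from compound 2 to compound 4 (0.12 log units; within the scatter), yet it stays clearly apart from pyridin-2-yl, with a 3.5-fold lower number from compound 1 to compound 4 (0.54 log units; beyond the scatter), which leaves pyridin-2-yl as the only one of the four groups that stands apart from the others. No measurement shown offers an explanation for either the sameness of the three groups or the difference of the fourth.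

Still open, as far as these compounds go, is whether a plain phenyl, a phenyl ring carrying an amine or a carboxylic acid, or a much shorter chain at this place would stay with compound 2, compound 3 and compound 4 or move towards compound 1. Also open, from the compounds shown here alone, is whether pyridin-3-yl or pyridin-4-yl would behave like pyridin-2-yl, and whether any group at this place can bring the number well below that of these three compounds.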